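Swapping the pyridine ring position on a bi-aryl tail

The source may report more compounds than this note shows. Statements on the series, on what has been measured and on what is new or still open speak of the compounds shown alone.

Compound 1 `O=C1C(=O)N(Cc2ccc(-c3ccncc3)cn2)c2ccc(OC(F)(F)F)cc21`: > 30000 nM
Compound 2 `O=C1C(=O)N(Cc2ccc(-c3cccnc3)cc2)c2ccc(OC(F)(F)F)cc21`: 1600 nM

In a functional assay on CHO cells for positive allosteric modulation of muscarinic acetylcholine receptor M5 (Homo sapiens), read by FLIPR and calcium flux, with a stated time of 1 h (a higher number here means that more compound is needed for the effect, a lower number that less compound is needed), compound 1 reaches only the limit of the assay, > 30000 nM, so no number is known for it, which is the meaning of the limit of > 30000 nM in this assay, at which 1 of the 2 values shown sits. Compound 2, in this assay, gives 1600 nM. Compound 2 differs from compound 1 in two places at once, so its value shows only that a pyridin-3-yl tail on a different ring can give a measurable effect.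

Compound 3 `O=C1C(=O)N(Cc2ccc(-c3cccnc3)cn2)c2ccc(OC(F)(F)F)cc21` has not been measured in this assay. It keeps the shared core and the ring of compound 1 but carries the change (pyridin-3-yl in place of pyridin-4-yl on an aromatic carbon), that is, pyridin-3-yl in place of pyridin-4-yl on an aromatic carbon, two atoms from the ring nitrogen and para to a large group. Within the data shown here, since no measured step covers this move alone, the expected step of an at least 3.3-fold lower number from compound 1 to compound 3 (0.52 log units; beyond the scatter) is a guess, toward needing less compound, as compound 2 shows a pyridin-3-yl tail can reach 1600 nM. Compound 3 is thus estimated at 9000 nM, within 2000 nM to 40000 nM.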

Compound 3, half-maximal effective concentration: > 30000 nM
Compound 3 gave a limit, no number; the forecaster's own chance of this, stated with the estimate: 40%; middle value at least 3.3-fold (0.52 log units) from the limit.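

In this assay compound 3 gives > 30000 nM, which is a limit and not a number. Among these compounds, compound 1 gives > 30000 nM, also a limit, so no step between compound 1 and compound 3 can be read: the limit of > 30000 nM in this assay, at which 2 of the 3 values shown sit. The compounds shown leave open whether pyridin-3-yl in place of pyridin-4-yl changes the effect at all on this tail.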